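Swapping the amide aryl group in a dihydrofuran series

The source may hold more compounds than are shown below. What is called first, only, known or untested is meant among the compounds shown, and "the series" means these compounds.

Compound 1 `C=CC1=C(C(=O)NCc2ccc(C)cc2)C(c2ccc(OC)cc2)OC1` gives 43100 nM in a functional assay on QGY7701 cells (Homo sapiens) for cytotoxicity, read by MTT assay, with a stated time of 24 h; on this read-out lower numbers stand for stronger inhibition and higher numbers for weaker inhibition.
Compound 2 `C=CC1=C(C(=O)Nc2ccccc2OC)C(c2ccc(OC)cc2)OC1` gives > 100000 nM in this assay, which is a limit of the assay.

Compound 2 therefore sits at the limit of > 100000 nM in this assay, at which 1 of the 2 values shown sits, with no number of its own. The change 4-methylphenyl in place of 2-methoxyphenyl on an amide-type nitrogen gives compound 3 `C=CC1=C(C(=O)Nc2ccc(C)cc2)C(c2ccc(OC)cc2)OC1`. Within the data shown here, the one step that bears on it, an at least 2.3-fold higher number from compound 1 to compound 2 (0.36 log units; beyond the scatter), ran in the opposite direction, so compound 3 is expected to give a somewhat lower number, an at least 1.3-fold lower number from compound 2 to compound 3 (0.12 log units; that floor lies within the scatter). Compound 3 is thus estimated at 75000 nM in this assay, within 30000 nM to 150000 nM.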

Compound 3, half-maximal inhibitory concentration: > 100000 nM
Compound 3 ended at the assay's limit; the forecaster's own chance of this, stated with the estimate: 45%; at least 1.3-fold (0.12 log units) between middle value and limit.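

In this assay, compound 3 gives a limit of the assay, not a number of its own: the limit of > 100000 nM in this assay, at which 2 of the 3 values shown sit. The step between compound 2 and compound 3 therefore cannot be read, and 2-methoxyphenyl and 4-methylphenyl cannot be ranked on this amide-type nitrogen. 4-Methylphenyl in place of 4-methylbenzyl gives an at least 2.3-fold higher number from compound 1 to compound 3 (0.36 log units; beyond the scatter), so the higher number seen with compound 2 does not depend on having the 2-methoxyphenyl group. On these data alone, whether a longer chain ending in an amine on this nitrogen would give a lower number than compound 1 remains open.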